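Naphthyl for Phenyl on Urea and Thiourea Analogues

A few compounds are considered here, and "the series" means these few. Any claim that something is new, unique, unknown or untested is made for them only; others in the source may bear on it.

Compound 1 `CN(c1cc2ncc(=O)[nH]c2cc1NC(=S)Nc1ccccc1)C1CCCCC1`: 49600 nM
Compound 2 `CN(c1cc2ncc(=O)[nH]c2cc1NC(=S)Nc1cccc2ccccc12)C1CCCCC1`: 43600 nM
Compound 3 `CN(c1cc2ncc(=O)[nH]c2cc1NC(=O)Nc1ccccc1)C1CCCCC1`: 5520 nM

Of the compounds shown here, three have been measured in an ADME assay on Huh-7 cells (Homo sapiens) for cytotoxicity; on this read-out lower numbers stand for stronger inhibition and higher numbers for weaker inhibition; the values stand in the list above. Compound 1 and compound 2 differ by naphthalen-1-yl in place of phenyl on an amide-type nitrogen, and that change gave a 1.1-fold lower number from compound 1 to compound 2 (0.06 log units; within the scatter). Compound 1 and compound 3 differ in their cores by a group of 9 heavy atoms (7 carbon, 1 nitrogen, 1 oxygen; one six-membered aromatic ring of carbon only) in place of a group of 9 heavy atoms (7 carbon, 1 nitrogen, 1 sulfur; one six-membered aromatic ring of carbon only), on a nitrogen on an aromatic ring, and here the step was larger: a 9.0-fold lower number from compound 1 to compound 3 (0.95 log units; beyond the scatter). Compound 3 thus holds the lowest number of the three, with compound 2 and compound 1 both beyond the scatter above it.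

Compound 4 `CN(c1cc2ncc(=O)[nH]c2cc1NC(=O)Nc1cccc2ccccc12)C1CCCCC1` has not yet been measured. It differs from compound 3 by naphthalen-1-yl in place of phenyl on an amide-type nitrogen. This is the same kind of change as that from compound 1 to compound 2, though the place is not identical: in compound 1 the amide-type nitrogen's other neighbour is a thiocarbonyl carbon, whereas in compound 3 it is a carbonyl carbon. The expectation for compound 4 therefore rests on compound 1 and compound 2, where the step was a 1.1-fold lower number from compound 1 to compound 2 (0.06 log units; within the scatter), and the expected step from compound 3 is accordingly small: a 1.1-fold lower number from compound 3 to compound 4 (0.04 log units; within the scatter). On that basis compound 4 is estimated at 5000 nM in this assay, with a likely range from 2000 nM to 13000 nM. Whether the carbonyl core carries the naphthyl change the same way as the thiocarbonyl core is exactly what the measurement will show.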

Compound 4, half-maximal inhibitory concentration: 5330 nM
The estimate for compound 4 lay 1.1-fold (0.03 log units) below the measured number; the range from low to high includes it.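

In this assay, naphthalen-1-yl in place of phenyl on the amide-type nitrogen, whose other neighbour here is a carbonyl carbon, gave a 1.0-fold lower number from compound 3 to compound 4 (0.02 log units; within the scatter), and this step agrees with the one seen on the thiocarbonyl core: the same change on two cores in this assay, a 1.1-fold lower number (0.06 log units; within the scatter) from compound 1 to compound 2 and a 1.0-fold lower number (0.02 log units; within the scatter) from compound 3 to compound 4, 1.1-fold (0.04 log units) apart, within the scatter of two such steps. Within this series, then, the change carried from one core to the other, and on neither core did the larger aromatic group move the number beyond the scatter. Among these compounds, this rests on only two matched pairs in a single read-out, however. Both steps are close to nothing, so the pairs show that a change without a clear effect stayed without one. They do not show that a change with a sizeable effect would transfer equally well, nor that other cores would behave in the same way.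

The compounds shown leave open whether the tolerance extends to other groups on that nitrogen, such as naphthalen-2-yl, a pyridine ring or a saturated cyclohexyl ring, or to a phenyl ring carrying a carboxylic acid or an amine. They also leave open whether the same holds when the cyclohexyl group on the shared core gives way to a morpholine or a longer chain.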